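The source may hold more compounds than are shown below. What is called first, only, known or untested is meant among the compounds shown, and "the series" means these compounds.

Compound 1, `COc1cc(C(=O)c2sc3ccccc3c2-c2ccccc2)cc(OC)c1OC`, gives 1500 nM in a functional assay on Jurkat cells (Homo sapiens) for antiproliferative activity, read by MTT assay, with a stated time of 72 h (a higher number here means a weaker inhibitor, a lower number a stronger inhibitor), the lowest of the three numbers shown. Compound 2, `COc1cc(C(=O)c2sc3ccccc3c2-c2ccc(F)cc2)cc(OC)c1OC`, gives 2300 nM, and compound 3, `COc1cc(C(=O)c2sc3ccccc3c2-c2ccc(C)cc2)cc(OC)c1OC`, gives 3300 nM. Each differs from compound 1 by one change on the phenyl group: a 1.5-fold higher number from compound 1 to compound 2 (0.19 log units; within the scatter), while a 2.2-fold higher number from compound 1 to compound 3 (0.34 log units; beyond the scatter). Compound 4, `COc1ccc(-c2c(C(=O)c3cc(OC)c(OC)c(OC)c3)sc3ccccc23)c(OC)c1`, takes a further step from compound 1: 2,4-dimethoxyphenyl in place of phenyl on an aromatic carbon. The two measured steps from compound 1 bear on this, since each also alters the phenyl group; one stayed within the scatter and the other rose modestly beyond it. A similar or somewhat larger rise in this assay is therefore expected, as a 2.0-fold higher number from compound 1 to compound 4 (0.30 log units; within the scatter). Compound 4 is estimated at 3000 nM, within a range from 1200 nM to 8000 nM.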

Compound 4, half-maximal inhibitory concentration: 4000 nM
For compound 4 the middle estimate is 1.3-fold (0.12 log units) below the measured one; the measured number falls inside the stated range.
By their numbers in this assay, from the lowest: compounds 1, 2, 3 and 4 (each within the scatter of the next, the first and the last beyond it).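

Enlarging the group on this aromatic carbon to 2,4-dimethoxyphenyl, with its 2 hydrogen-bond acceptors, gives the clearest rise so far in this assay (a 2.7-fold higher number from compound 1 to compound 4 (0.43 log units; beyond the scatter)), yet activity is not lost. Compound 4 cannot be separated from the singly substituted phenyl compounds (a 1.2-fold higher number from compound 3 to compound 4 (0.08 log units; within the scatter); a 1.7-fold higher number from compound 2 to compound 4 (0.24 log units; within the scatter)). Nothing available explains the rise.

Going by these compounds, whether a single methoxy group would give the same number remains open. So does whether a hydroxyl or an amine on this phenyl would bring the number below that of compound 1.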